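The source may hold more compounds than are shown below. What is called first, only, known or untested is meant among the compounds shown, and "the series" means these compounds.

The measured compounds in an assay on isolated protein for inhibition of Caspase-8 (Homo sapiens); a higher number here means a weaker inhibitor, a lower number a stronger inhibitor:
Compound 1, `O=C1C[C@H](NC(=O)[C@@H]2COC[C@@H]3CCCC[C@H](NC(=O)c4nccc5ccccc45)C(=O)N32)C(O)O1`, gives 264 nM.
Compound 2, `O=C1C[C@H](NC(=O)[C@@H]2CN(C(=O)Nc3ccccc3)C[C@@H]3CCCC[C@H](NC(=O)c4ccccc4)C(=O)N32)C(O)O1`, gives 601 nM.
Compound 3, `O=C1C[C@H](NC(=O)[C@@H]2COC[C@@H]3C/C=C\C[C@H](NC(=O)c4cccc(Cl)c4)C(=O)N32)C(O)O1`, gives 1550 nM.

Of these three, compound 3 has the highest number in this assay, so it is the weakest inhibitor shown so far; the numbers of compound 2 and compound 1 both lie below it by more than the usual scatter, with compound 2 the nearest and compound 1 the furthest.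

Compound 4, `O=C1C[C@H](NC(=O)[C@@H]2COC[C@@H]3C/C=C\C[C@H](NC(=O)c4ccccc4C(F)(F)F)C(=O)N32)C(O)O1`, has not yet been measured. It differs from compound 3 in one place: 2-(trifluoromethyl)phenyl in place of 3-chlorophenyl on a carbonyl carbon. The shared core and everything else in the molecule stay as in compound 3.

Among the compounds with values here, no measured pair shows this particular change, so there is no step to lean on. The three measured compounds differ from each other in several places at once, and their numbers say nothing about replacing one ring for another on a carbonyl carbon. Without such a step, the step of a 1.0-fold lower number from compound 3 to compound 4 (0.01 log units; within the scatter) is expected to lie within the scatter, in either direction. The estimate for compound 4 in this assay is 1500 nM, with a range from 500 nM to 4500 nM.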

Compound 4, half-maximal inhibitory concentration: 670 nM
The estimate for compound 4 lay 2.2-fold (0.35 log units) above the measured number, and the stated range covers the measured number.
By their numbers in this assay, from the lowest: compound 1; then compounds 2 and 4 (each within the scatter of the next); then compound 3.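

In this assay, putting 2-(trifluoromethyl)phenyl in place of 3-chlorophenyl on a carbonyl carbon whose other neighbour is an amide-type nitrogen gives a 2.3-fold lower number from compound 3 to compound 4 (0.36 log units; beyond the scatter), a modest step that shows the number can move with this ring alone while the shared core stays fixed. The entering group has more heavy atoms than the one it replaces, yet both have one six-membered aromatic ring of carbon only and neither has a hydrogen-bond donor or acceptor, and the names show that the substituent and its numbered place on the ring both change, so this one step cannot separate the two. Nothing measured here bears on why the number moves.

From the compounds shown here alone, whether 2-chlorophenyl or 3-(trifluoromethyl)phenyl would fall nearer compound 3 or compound 4 stays open, and so does the effect of a ring carrying an amine or a carboxylic acid on this carbonyl. Also open, going by these compounds, is whether the same swap would give a similar step on a different core, such as that of compound 1 or compound 2.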